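A few compounds are considered here, and "the series" means these few. Any claim that something is new, unique, unknown or untested is made for them only; others in the source may bear on it.

Compound 1 `Fc1cccc(N2CCN(CCCOc3ccc4c(c3)CCC4)CC2)c1` and compound 2 `Clc1ccc(N2CCN(CCCCOc3ccc4c(c3)CCC4)CC2)cc1` share a core and were both tested in a functional assay on the whole organism for inhibition, with Mus musculus as the target, at a dose of 25 mg/kg by the oral route; on this read-out lower numbers stand for less inhibition and higher numbers for more inhibition at the one dose given (going by the name of the read-out). In this assay compound 1 gives 19%, the lower of the two numbers, while compound 2 gives 31%, a gap beyond the usual scatter. Compound 3 `CC(=O)c1ccc(N2CCN(CCCOc3ccc4c(c3)CCC4)CC2)cc1` has not yet been measured. It differs from compound 1 in one place: 4-acetylphenyl in place of 3-fluorophenyl on an amine nitrogen in a ring. Within the data shown here, no measured pair shows this change, so its effect is unknown; only a small rise is expected, a step of a number 8 percentage points higher from compound 1 to compound 3 (within the scatter) that may well stay within the scatter. Compound 3 is therefore estimated to give 27%, between 10% and 48%.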

Compound 3, a percentage reported as inhibition, in the whole organism at one dose (the size of the read-out at that dose, not a potency): 13%
Estimate against measurement, compound 3: 14 percentage points above; measured number inside the range.
By their numbers in this assay, from the lowest: compounds 3 and 1 (each within the scatter of the next); then compound 2.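

In this assay, replacing 3-fluorophenyl with 4-acetylphenyl on the amine nitrogen in the ring gives a number 6 percentage points lower from compound 1 to compound 3 (within the scatter). At this position, then, the read-out does not separate the two aryl groups, even though the new one brings a carbonyl and a hydrogen-bond acceptor. The change alters both the group and where it sits on the aromatic ring, so these two parts cannot be told apart here. A 4-fluorophenyl group could separate them, while an amine or a carboxylic acid on the aromatic ring remains an open test of this position. No measurement shown here explains the result.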